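A fused ring returns to the carbonyl carbon

The source may report more compounds than this note shows. Statements on the series, on what has been measured and on what is new or still open speak of the compounds shown alone.

Within the data shown here, compound 1 `O=C(NC(=S)N1CCc2c(OCCCCCOc3ccc(Cl)cc3)cccc21)c1ccc(C(F)(F)F)cc1` is the one member of this pair with a full number: in an ADME assay on Huh-7 cells (Homo sapiens) for cytotoxicity (a lower number here means that less compound is tolerated, a higher number that more compound is tolerated), compound 1 gives 32700 nM. Compound 2 `O=C(CCc1ccccc1)NC(=S)N1CCc2c(OCCCCCOc3ccc(Cl)cc3)cccc21` is reported in this assay only as a limit, > 50000 nM, so no exact number exists for compound 2. From the compounds shown here alone, the change between these two is recorded as an at least 1.5-fold higher number from compound 1 to compound 2 (0.18 log units; that floor lies within the scatter), and that step rests on (the limit of > 50000 nM in this assay, at which 1 of the 2 values shown sits), which means its true size is unknown beyond its floor.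

Compound 3 `O=C(NC(=S)N1CCc2c(OCCCCCOc3ccc(Cl)cc3)cccc21)c1ccc2ccccc2c1` differs from compound 2 by naphthalen-2-yl in place of phenethyl on a carbonyl carbon. Among the measured compounds shown here, the single measured step bearing on this runs in the opposite direction: it replaced an aromatic ring sitting directly on the carbonyl carbon with phenethyl and gave an at least 1.5-fold higher number from compound 1 to compound 2 (0.18 log units; that floor lies within the scatter). Placing an aromatic ring back on the carbonyl carbon in compound 3 is therefore expected to bring the number back toward that of compound 1, an estimated at least 1.7-fold lower number from compound 2 to compound 3 (0.25 log units; that floor lies within the scatter) in this assay. Compound 3 is thus expected to fall near 28000 nM, with a range from 10000 nM to 60000 nM, and a fair chance remains that only a limit is reported.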

Compound 3, half-maximal cytotoxic concentration: > 50000 nM
Compound 3: only a limit was reported (the forecaster's own chance of this, stated with the estimate: 35%); middle value at least 1.7-fold (0.25 log units) away from the limit.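

In this assay compound 3 is reported only as a limit, > 50000 nM. Naphthalen-2-yl in place of 4-(trifluoromethyl)phenyl on the carbonyl carbon gives an at least 1.5-fold higher number from compound 1 to compound 3 (0.18 log units; that floor lies within the scatter), so an aromatic ring sitting directly on that carbon can also end at the limit, as the phenethyl group does, although this floor does not show that compound 3 truly differs from compound 1. The step joining the phenethyl and naphthalen-2-yl compounds cannot be read, and the step from compound 1 has only a floor, because these values stop at the same limit: the limit of > 50000 nM in this assay, at which 2 of the 3 values shown sit.

From the compounds shown here alone, compound 1 alone carries a full number, so how far compound 2 and compound 3 really lie from it, and whether they differ from each other, stays open. Also open, going by these compounds, is what a plain phenyl ring, or a phenyl ring carrying a carboxylic acid or an amine, would give on the same carbonyl carbon, which would help show whether the trifluoromethyl group or the ring itself goes with the full number of compound 1.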